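Working notes on the series: compound 4 expected

The source may report more compounds than this note shows. Statements on the series, on what has been measured and on what is new or still open speak of the compounds shown alone.

Three measured compounds share one core and differ in a single group on an aromatic carbon. Compound 1 `CNc1ccc(Nc2nccc(-c3cccnc3)n2)cc1` carries methylamino, and in a functional assay for inhibition, with Homo sapiens as the target (on this read-out lower numbers stand for stronger inhibition and higher numbers for weaker inhibition), compound 1 gives 2100 nM. Compound 2 `COc1ccc(Nc2nccc(-c3cccnc3)n2)cc1` carries methoxy; in this assay compound 2 gives 1700 nM. Compound 3 `CC(C)(C)c1ccc(Nc2nccc(-c3cccnc3)n2)cc1` carries tert-butyl; in this assay compound 3 gives 600 nM, the lowest of the three numbers, with compound 2 nearest and compound 1 furthest. The steps toward it are a 3.5-fold lower number from compound 1 to compound 3 (0.54 log units; beyond the scatter) and a 2.8-fold lower number from compound 2 to compound 3 (0.45 log units; beyond the scatter), whereas a 1.2-fold lower number from compound 1 to compound 2 (0.09 log units; within the scatter).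

Compound 4 `Oc1ccc(Nc2nccc(-c3cccnc3)n2)cc1` is not yet measured. Its change from compound 3: hydroxy in place of tert-butyl on an aromatic carbon. Hydroxy, like methylamino and methoxy, brings a hydrogen-bond acceptor where tert-butyl brought none, and the two steps that bear on this both ran the other way: tert-butyl entering in place of either of those groups lowered the number. The expectation is therefore a rise in this assay of about the size of a 2.8-fold lower number from compound 2 to compound 3 (0.45 log units; beyond the scatter), reversed. The step expected is a 3.0-fold higher number from compound 3 to compound 4 (0.48 log units; beyond the scatter). For compound 4 the estimated value in this assay is 1800 nM, with a range from 900 nM to 3600 nM.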

Compound 4, half-maximal inhibitory concentration: 5100 nM
The estimate for compound 4 lay 2.8-fold (0.45 log units) below the measured number; the whole stated range lies below it.
By their numbers in this assay, from the lowest: compound 3; then compounds 2 and 1 (each within the scatter of the next); then compound 4.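

In this assay this position separates groups that compounds 1 and 2 could not: methoxy and methylamino stood within the scatter of each other, while hydroxy gives a 3.0-fold higher number from compound 2 to compound 4 (0.48 log units; beyond the scatter) and a 2.4-fold higher number from compound 1 to compound 4 (0.39 log units; beyond the scatter), so removing the methyl from the oxygen matters here. The change from tert-butyl, with four carbons leaving and one oxygen bringing a hydrogen-bond donor and acceptor, gives an 8.5-fold higher number from compound 3 to compound 4 (0.93 log units; beyond the scatter) and spans the two ends of the series. Tert-butyl and hydroxy thus mark the ends of the range at this carbon, and the three groups with a heteroatom do not behave as one class. Nothing available on these compounds accounts for the size of this rise.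

Still open, on these data alone, is whether the rise belongs to hydroxy alone or also comes with an unsubstituted amino group, and whether carbon groups smaller than tert-butyl, such as methyl or isopropyl, keep the low number of compound 3. A carboxylic acid or a primary amide on this carbon would show how far the trend toward higher numbers extends.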